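Series notes: from compound 3 to compound 4

A few compounds are considered here, and "the series" means these few. Any claim that something is new, unique, unknown or untested is made for them only; others in the source may bear on it.

Measured so far:
- compound 1 `COc1ccc(-c2ccc(NC3=CC(=O)c4ncncc4C3=O)cc2)cc1`: 2300 nM
- compound 2 `O=C1C=CC(=O)c2ncncc21`: 18000 nM
- compound 3 `O=C1C(Nc2ccc(Oc3ccccc3)cc2)=CC(=O)c2ncncc21`: 1800 nM

In a functional assay on PANC-1 cells (Homo sapiens) for cytotoxicity, read by MTT assay, with a stated time of 72 h (a lower number here means a stronger inhibitor, a higher number a weaker inhibitor), compound 3 holds the lowest number of the three. Compound 1 sits within the scatter of it; compound 2, the bare shared core, lies beyond it, a markedly higher number. Among the compounds with values here, the only measured step, a 1.3-fold lower number from compound 1 to compound 3 (0.11 log units; within the scatter), exchanged one aromatic group for another on the anilino ring and stayed within the scatter.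

Compound 4 `COc1ccc(NC2=CC(=O)c3ncncc3C2=O)cc1` differs from compound 3 in one place: methyl in place of phenyl on an oxygen on an aromatic ring. Within the data shown here, no measured step removes a ring outright. The step from compound 1 to compound 3 bears on it only by showing that the choice between two aromatic groups at this part of the molecule made no difference beyond the scatter. Compound 2 shows that losing the whole anilino substituent weakens the compound a great deal, yet compound 4 keeps that substituent and loses only the phenyl. A small weakening is therefore expected, a 2.2-fold higher number from compound 3 to compound 4 (0.35 log units; beyond the scatter), possibly none beyond the scatter. Compound 4 is estimated at 4000 nM, in the range 1500 nM to 12000 nM.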

Compound 4, half-maximal inhibitory concentration: 800 nM
Compound 4: the middle estimate sits 5.0-fold (0.70 log units) above what was measured; the measured number lies below the stated range.
By their numbers in this assay, from the lowest: compound 4; then compounds 3 and 1 (each within the scatter of the next); then compound 2.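

In this assay, the second aromatic ring on this oxygen is not required for activity: a 2.3-fold lower number from compound 3 to compound 4 (0.35 log units; beyond the scatter), with methyl in place of phenyl, and the change lies beyond the scatter. The direct comparison with the other aromatic group points the same way, a 2.9-fold lower number from compound 1 to compound 4 (0.46 log units; beyond the scatter), whereas the earlier exchange between the two larger groups stayed within the scatter. Nothing available explains why the smaller group gives the lower number.

Still open, as far as these compounds go, is how far this runs among small groups on the oxygen: an ethyl group or a bare hydroxyl would show whether methyl itself matters or only the loss of phenyl. A dimethylamino group in place of methoxy would test whether the oxygen is needed at all.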